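Removing the methyl from compound 3: what cytotoxicity to expect

The compounds below may be only part of what the source reports. "The series", "measured", "known", "first", "only" and "open" are said of these compounds alone.

Compound 3 `COc1ccc(CN(C)c2cc(=O)c3cc(C(F)(F)F)cc([N+](=O)[O-])c3s2)cc1OC` was tested in an ADME assay on Vero cells (Chlorocebus sabaeus) for cytotoxicity, read by MTT assay, with a stated time of 48 h; a lower number here means a stronger inhibitor, a higher number a weaker inhibitor. In this assay compound 3 gives > 64 ug/mL, a limit of the assay and not a number. Compound 1 `O=c1cc(NCc2ccccc2)sc2c([N+](=O)[O-])cc(C(F)(F)F)cc12` in this assay gives > 64 ug/mL, likewise a limit. Compound 2 `O=c1cc(NCc2cccc(F)c2)sc2c([N+](=O)[O-])cc(C(F)(F)F)cc12` in this assay gives > 64 ug/mL, also a limit. Among the measured compounds shown here, the only step among the measured compounds, a step that the two limits leave unreadable from compound 1 to compound 2, cannot be read, since all three values sit at the limit of > 64 ug/mL in this assay, at which 3 of the 3 values shown sit. Compound 4 `COc1ccc(CNc2cc(=O)c3cc(C(F)(F)F)cc([N+](=O)[O-])c3s2)cc1OC` differs from compound 3 by hydrogen in place of methyl on a nitrogen on an aromatic ring. For the measured compounds named here, no measured step bears on this change, so the step that the limit leaves unreadable from compound 3 to compound 4 is expected to be none beyond the scatter. Compound 4 is therefore estimated at 80 ug/mL, within 40 ug/mL to 200 ug/mL, most likely again reported only as a limit.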

Compound 4, half-maximal inhibitory concentration: > 64 ug/mL
Compound 4: a limit, no number (the forecaster's own chance of this, stated with the estimate: 85%); the middle value is on the limit's open side.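

No step from compound 1, compound 2 or compound 3 to compound 4 can be read in this assay, where every value is a limit of the assay and not a number: the limit of > 64 ug/mL in this assay, at which 4 of the 4 values shown sit.

The compounds shown leave open whether hydrogen in place of methyl, or 3,4-dimethoxyphenyl in place of phenyl or 3-fluorophenyl, changes cytotoxicity at all.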